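Chloro for Bromo: An Expected Small Step

The compounds below may be only part of what the source reports. "The series", "measured", "known", "first", "only" and "open" are said of these compounds alone.

Compounds measured in a functional assay on the whole organism (Abdomen, strain Swiss albino) with Mus musculus as the target, with stated times of 10 min and 5 min, at a dose of 30 mg/kg by the oral route; on this read-out higher numbers stand for a stronger effect at the one dose given and lower numbers for a weaker effect:
compound 1 `O=C1C2ON=C(c3cn(-c4ccccc4)nc3-c3ccc(Cl)cc3)C2C(=O)N1c1ccccc1` gives 43.2%
compound 2 `Brc1ccc(-c2nn(-c3ccccc3)cc2-c2cc(-c3ccccc3)on2)cc1` gives 31.4%

Compound 2 stands lowest of these two numbers; its nearest neighbour, compound 1, lies higher by an amount beyond the scatter. Because the two structures differ in more than one place, their two values show only that gap and nothing more. Compound 3 `Clc1ccc(-c2nn(-c3ccccc3)cc2-c2cc(-c3ccccc3)on2)cc1` has not yet been measured and differs from compound 2 in a single place: chloro in place of bromo on an aromatic carbon. One halogen replaces another on the same aromatic carbon, with no change in rings, hydrogen-bond donors, hydrogen-bond acceptors or charge. Going by the values given here, no measured pair shows such a step, so for compound 3 in this assay the expected change is one within the scatter, with no preferred direction, namely a number 0.6 percentage points higher from compound 2 to compound 3 (within the scatter). Compound 3 is therefore estimated at 32%, with a range from 20% to 45%.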

Compound 3, a percentage reported as activity, at one dose (the size of the read-out at that dose, not a potency): 49%
For compound 3 the middle estimate is 17 percentage points below the measured one; the whole stated range lies below it.
By their numbers in this assay, from the lowest: compound 2; then compounds 1 and 3 (each within the scatter of the next).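

The change from 4-bromophenyl to 4-chlorophenyl gives a number 17.6 percentage points higher from compound 2 to compound 3 (beyond the scatter) in this assay and shows that this aromatic carbon, para to a large group, is not indifferent to which of these two halogens it carries. The earlier compounds shown here could not show this: compound 1 and compound 2 differ in more than one place, whereas here the rings, hydrogen-bond donors, hydrogen-bond acceptors and net charge stay the same and the read-out still moves beyond the scatter. Nothing measured in this account explains the step.

On these data alone, it remains open whether fluoro, a methoxy group or an amine on the same carbon would continue this rise or reverse it. Also open, as far as these compounds go, is whether bromo in place of chloro on the core of compound 1 would give a step of similar size.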